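The source may report more compounds than this note shows. Statements on the series, on what has been measured and on what is new or still open speak of the compounds shown alone.

Measured compounds in a functional assay on HT-29 cells (Homo sapiens) for antiproliferative activity, read by MTT assay, with a stated time of 96 h; a higher number here means a weaker inhibitor, a lower number a stronger inhibitor:
- compound 1 `CN(C)c1ccc(N2C(=O)NC3(CSC4=C3C(=O)c3ncccc3C4=O)C2=O)cc1`: 20 nM
- compound 2 `COc1ccc(N2C(=O)NC3(CSC4=C3C(=O)c3ncccc3C4=O)C2=O)cc1`: 2 nM
- compound 3 `O=C1C2=C(C(=O)c3ncccc31)C1(CS2)NC(=O)N(c2ccccc2)C1=O`: 2 nM

Compound 3 stands level with compound 2 at the digits reported, the two together giving the lowest numbers of the three; compound 1 sits furthest away, a 10-fold lower number from compound 1 to compound 3 (1.00 log units; beyond the scatter). The unmeasured compound 4 `CCCCCc1ccc(N2C(=O)NC3(CSC4=C3C(=O)c3ncccc3C4=O)C2=O)cc1` carries pentyl in place of hydrogen on an aromatic carbon.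

The step from compound 3 to compound 4 is a substitution at the same place where the three measured compounds already vary. The nearest comparison is no change at the digits printed from compound 2 to compound 3 (within the scatter), which shows that methoxy at this position is neutral. Against that, a 10-fold lower number from compound 1 to compound 2 (1.00 log units; beyond the scatter) and a 10-fold lower number from compound 1 to compound 3 (1.00 log units; beyond the scatter) show that dimethylamino at the same position gives a clearly higher number. For the measured compounds named here, no measured compound carries an alkyl chain there, so the direction for pentyl is not fixed by the data; substitution at this site has so far been either neutral or unfavourable, never favourable. The expected step is therefore a 2.5-fold higher number from compound 3 to compound 4 (0.40 log units; beyond the scatter), with a range that allows for no change.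

Compound 4 is estimated at 5 nM, between 1.5 nM and 20 nM.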

Compound 4, half-maximal inhibitory concentration: 250 nM
Estimate against measurement, compound 4: 50-fold (1.70 log units) below, outside the stated range (above it).
By their numbers in this assay, from the lowest: compounds 2 and 3 (each within the scatter of the next); then compound 1; then compound 4.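

In this assay, this position proves far from indifferent to substitution: pentyl in place of hydrogen gives a 130-fold higher number from compound 3 to compound 4 (2.10 log units; beyond the scatter), and pentyl in place of methoxy gives a 130-fold higher number from compound 2 to compound 4 (2.10 log units; beyond the scatter). Pentyl also fares worse than dimethylamino, with a 13-fold higher number from compound 1 to compound 4 (1.10 log units; beyond the scatter), so the dimethylamino penalty does not mark the limit of what a group on this aromatic carbon can cost. No measured evidence on the compounds shown accounts for the loss.

On these data alone, whether the loss tracks chain length stays open: methyl, ethyl and a longer chain such as heptyl would show whether it rises steadily or appears abruptly. Also open, as far as these compounds go, is whether a branched group such as tert-butyl, or a pentyl chain ending in a hydroxyl or an amine, behaves like pentyl itself.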